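Swapping an acetamido for a hydroxy: effect on acid dissociation

The compounds below may be only part of what the source reports. "The series", "measured", "known", "first", "only" and "open" are said of these compounds alone.

Measured so far:
compound 1 `CC(=O)Nc1ccc(OC(=S)Nc2ccc(Nc3ccc([N+](=O)[O-])cc3)cc2)cc1` gives 9.04 in a physicochemical assay for acid dissociation.
compound 2 `CC(=O)Nc1ccc(OC(=S)Nc2ccc(Nc3ccc(C(F)(F)F)cc3)cc2)cc1` gives 9.05.

Going by the values given here, compound 2 stands highest of the two, yet its nearest neighbour is compound 1, with the only measured step, a number 0.01 log units higher from compound 1 to compound 2 (within the scatter), lying within the scatter. Compound 3 `Oc1ccc(OC(=S)Nc2ccc(Nc3ccc(C(F)(F)F)cc3)cc2)cc1` differs from compound 2 by hydroxy in place of acetamido on an aromatic carbon. Among the compounds with values here, no measured step touches this kind of change; the single step, from a nitro to a trifluoromethyl, offers no guide. Without a comparable precedent, the change from compound 2 to compound 3 is expected to be a number 0.05 log units lower from compound 2 to compound 3 (within the scatter), a step not beyond the scatter. Compound 3 is therefore estimated at 9, ranging from 8.3 to 9.7.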

Compound 3, acid dissociation constant: 9.23
Compound 3: the middle estimate sits 0.23 log units below what was measured, within the range that was stated.
By their numbers in this assay, from the lowest: compounds 1, 2 and 3 (each within the scatter of the next).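

In this assay, exchanging 4-acetamidophenyl for 4-hydroxyphenyl gives a number 0.18 log units higher from compound 2 to compound 3 (within the scatter). So at this position, para to a large group, replacing an acetamido of four heavy atoms with a hydroxy of one heavy atom leaves the reading within the usual spread of repeats, a place the earlier step, from nitro to trifluoromethyl, did not touch. No measurement is at hand that could explain this result. On these data alone, whether an amine or a methoxy group on the same carbon would also stay within the scatter remains open, as does whether hydroxy in place of acetamido gives a similar result with nitro instead of trifluoromethyl.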